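Series notes: amine replacements on the shared core

The source may hold more compounds than are shown below. What is called first, only, known or untested is meant among the compounds shown, and "the series" means these compounds.

Measured compounds:
compound 1 `N#CC1=C(N)N(c2ccc(S(N)(=O)=O)cc2)C2=C(C(=O)CCC2)C1c1ccc(Cl)cc1Cl`, 50%
compound 2 `CCCCNC(=S)NC1=C(C#N)C(c2ccc(Cl)cc2Cl)C2=C(CCCC2=O)N1c1ccc(S(N)(=O)=O)cc1`, 30%
compound 3 `N#CC1=C(NC(N)=O)N(c2ccc(S(N)(=O)=O)cc2)C2=C(C(=O)CCC2)C1c1ccc(Cl)cc1Cl`, 35%

In a functional assay on Ehrlich cells (Mus musculus) for cytotoxicity, read by trypan blue exclusion, with a stated time of 2 h, tested at 25 ug/mL (a lower number here means a weaker effect, a higher number a stronger effect of the compound at the concentration tested), compound 1 stands highest of the three numbers; compound 3 is nearest and compound 2 furthest. Compound 4 `N#CC1=C(N2C(=O)CCC2=O)N(c2ccc(S(N)(=O)=O)cc2)C2=C(C(=O)CCC2)C1c1ccc(Cl)cc1Cl` is not yet measured. Its change from compound 1: 2,5-dioxopyrrolidin-1-yl in place of amino on a double-bonded ring carbon. Both measured steps alter the same amine nitrogen of compound 1 and both lower the read-out: a number 20 percentage points lower from compound 1 to compound 2 (beyond the scatter) and a number 15 percentage points lower from compound 1 to compound 3 (beyond the scatter). Between the two substituted compounds the difference is small, a number 5 percentage points higher from compound 2 to compound 3 (within the scatter). Compound 4 removes the amino group entirely rather than substituting on it, so the nearest guide is the direction and size of those two steps. A modest fall beyond the scatter is expected, a number 17 percentage points lower from compound 1 to compound 4 (beyond the scatter). Compound 4 is estimated at 33%, within 20% to 50%.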

Compound 4, a percentage reported as activity, at one concentration (the size of the read-out at that concentration, not a potency): 50%
Beside the measured number, compound 4's estimate is 17 percentage points below it, within the range that was stated.
By their numbers in this assay, from the lowest: compounds 2 and 3 (each within the scatter of the next); then compounds 1 and 4 (each within the scatter of the next).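

In this assay, 2,5-dioxopyrrolidin-1-yl in place of amino gives no change at the digits printed from compound 1 to compound 4 (within the scatter), so a free amino group is not required at this position for the read-out at the concentration tested. The falls seen with the two earlier replacements therefore do not extend to every replacement of amino: the ring-bearing compound gives a number 15 percentage points higher from compound 3 to compound 4 (beyond the scatter) and a number 20 percentage points higher from compound 2 to compound 4 (beyond the scatter). No available evidence accounts for these differences. As far as these compounds go, it remains open whether an acetylamino group or a dimethylamino group at this position would keep the read-out or lower it.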